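A methoxy for a methyl on the sulfonyl ring

The compounds below may be only part of what the source reports. "The series", "measured", "known", "first", "only" and "open" are said of these compounds alone.

Of the compounds shown here, two of this family have been tested in a functional assay on MCF7 cells (Homo sapiens) for antiproliferative activity, read by MTT assay; a lower number here means a stronger inhibitor, a higher number a weaker inhibitor. Compound 1, `COc1ccc(Nc2ccnc(Nc3ccc(NS(=O)(=O)c4ccc(OC)cc4)cc3)n2)cc1`, gives 29000 nM. Compound 2, `COc1cc(Nc2ccnc(Nc3ccc(NS(=O)(=O)c4ccc(C)cc4)cc3)n2)cc(OC)c1OC`, gives only > 50000 nM, which is a limit of the assay and not a number. Compound 2 thus stands at the weak end of what has been seen, at the limit of > 50000 nM in this assay, at which 1 of the 2 values shown sits. Compound 1 and compound 2 differ in more than one place, so their two values are set side by side without a step between them.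

Compound 3, `COc1ccc(S(=O)(=O)Nc2ccc(Nc3nccc(Nc4cc(OC)c(OC)c(OC)c4)n3)cc2)cc1`, is compound 2 with a single change: methoxy in place of methyl on an aromatic carbon. For the measured compounds named here, no step of this kind between measured compounds exists here. Compound 1 carries the same methoxyphenylsulfonyl group and gives 29000 nM, itself a weak value. For compound 3 a step of an at least 1.2-fold lower number from compound 2 to compound 3 (0.09 log units; that floor lies within the scatter) is expected, which is no more than the scatter of repeated measurement, so compound 3 is expected to remain weak. Compound 3 is estimated at 40000 nM, with a range from 15000 nM to 100000 nM.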

Compound 3, half-maximal inhibitory concentration: 9700 nM
Compound 3: middle estimate off by 4.1-fold (0.62 log units), on the high side; measured number below the stated range.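

In this assay, for the compounds shown here, methoxy in place of methyl on the aromatic carbon para to a large group, that is (4-methylphenyl)sulfonyl to (4-methoxyphenyl)sulfonyl, gives an at least 5.1-fold lower number from compound 2 to compound 3 (0.71 log units; beyond the scatter), the first single change that can be read in this family, and it brings the series from the limit to a measured number. On these data alone, the value of compound 2 is a limit of the assay and not a number, so the size of this step has only a floor and its true size stays unknown: the limit of > 50000 nM in this assay, at which 1 of the 3 values shown sits. With the (4-methoxyphenyl)sulfonyl group held fixed, 3,4,5-trimethoxyphenyl in place of 4-methoxyphenyl on the nitrogen at the other end of the molecule gives a 3.0-fold lower number from compound 1 to compound 3 (0.48 log units; beyond the scatter), so a change at either end of compound 3 moves the number beyond the scatter.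

As far as these compounds go, whether a hydroxy group, an amine or a chlorine at the place of the methoxy would go further or fall back remains open. Also open, from the compounds shown here alone, is whether the step from methyl to methoxy would hold with 4-methoxyphenyl rather than 3,4,5-trimethoxyphenyl on the nitrogen.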